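Replacing a chain tetrazole with a shorter carboxylic acid

This account rests on a few compounds, and the source may have more. Where it says the series, first, only, none or still open, it means among the compounds named here.

Compound 2 `CCc1cc(C(C)=O)c(O)cc1OCCCCCC(C)(C)c1nnn(C)n1` is one of two measured compounds built on the shared core. In an assay on isolated protein for inhibition of leukotriene B4 receptor 1 (Homo sapiens), tested at 10 uM (on this read-out lower numbers stand for less inhibition and higher numbers for more inhibition at the one concentration tested (going by the name of the read-out)), compound 2 gives 95%. Among the compounds with values here, its only neighbour, compound 1 `CCc1cc(C(C)=O)c(O)cc1OCCCCCC(C)(C)C#N`, gives in this assay a value of 85%, so that a number 10 percentage points higher from compound 1 to compound 2 (within the scatter), and the two numbers lie within the scatter of each other.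

Compound 3 `CCc1cc(C(C)=O)c(O)cc1OCCCCCCC(=O)O` has not yet been measured. It differs from compound 2 in one place: carboxymethyl in place of 1-methyl-1-(2-methyl-2H-tetrazol-5-yl)ethyl on a saturated chain carbon, five bonds along the chain from an oxygen on an aromatic ring. Within the data shown here, the single measured step exchanged a nitrile for a tetrazole on the same chain carbon and stayed within the scatter, so it bears only loosely on a change that removes that carbon with its attached groups and shortens the chain into carboxymethyl. Among the measured compounds shown here, with no closer precedent, the writer expects for compound 3 a step of a number 15 percentage points lower from compound 2 to compound 3 (beyond the scatter) in this assay, of uncertain direction. He estimates compound 3 at 80%, with a range from 50% to 100%.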

Compound 3, a percentage reported as inhibition, at one concentration (the size of the read-out at that concentration, not a potency): 87%
For compound 3 the middle estimate is 7 percentage points below the measured one, and the stated range covers the measured number.
By their numbers in this assay, from the lowest: compounds 1, 3 and 2 (each within the scatter of the next).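

In this assay, carboxymethyl at this place on the chain gives a number 8 percentage points lower from compound 2 to compound 3 (within the scatter), and the same group set against the nitrile gives a number 2 percentage points higher from compound 1 to compound 3 (within the scatter). The earlier step had only exchanged one group for another on a chain carbon that stayed in place, whereas these two steps show that the whole 1-methyl-1-(2-methyl-2H-tetrazol-5-yl)ethyl or 1-cyano-1-methylethyl group can give way to carboxymethyl with no change beyond the scatter at the one concentration tested. No available evidence accounts for this result.

On these data alone, the three compounds cannot be told apart at this single concentration, so any differences in potency among them remain open. Also open, as far as these compounds go, is how an amine, a methyl ester or a longer chain would read at this place.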